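The compounds below may be only part of what the source reports. "The series", "measured", "known", "first", "only" and "open" are said of these compounds alone.

The series shares one core, seen in compound 1 `COc1cc[nH]c1/C=C1\C(=O)Nc2ccc(F)c(I)c21`, compound 2 `COc1cc[nH]c1/C=C1\C(=O)Nc2ccc(F)c(C#CC(O)CN)c21` and compound 3 `CN[C@@H](C#Cc1c(F)ccc2c1/C(=C/c1[nH]ccc1OC)C(=O)N2)CO`, and differs at a single aromatic carbon. In a functional assay on MDA-MB-435 cells (Homo sapiens) for inhibition (a lower number here means a stronger inhibitor, a higher number a weaker inhibitor), compound 1 reaches only the limit of the assay, > 30000 nM. Compound 2 gives 130 nM in this assay, and compound 3 gives 300 nM. Both replacements of iodo are large: an at least 230-fold lower number from compound 1 to compound 2 (2.36 log units; beyond the scatter) and an at least 100-fold lower number from compound 1 to compound 3 (2.00 log units; beyond the scatter), and these steps are bounds rather than numbers because of the limit of > 30000 nM in this assay, at which 1 of the 3 values shown sits. Within the two numbers known, compound 3 stands highest, with compound 2 its only neighbour: a 2.3-fold higher number from compound 2 to compound 3 (0.36 log units; beyond the scatter).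

Compound 4 `COc1cc[nH]c1/C=C1\C(=O)Nc2ccc(F)c(C#C[C@@H]3C[C@H](O)CN3)c21` has not been measured. It changes the group on the triple-bonded carbon: 4-hydroxypyrrolidin-2-yl in place of 2-hydroxy-1-(methylamino)ethyl on a triple-bonded carbon. Going by the values given here, the only measured step at this position is the modest one from compound 2 to compound 3, where the arrangement of amine and hydroxyl around the chain changed; no measured step joins such a chain into a ring. The writer therefore expects compound 4 to sit close to compound 3 in this assay, with a step of a 1.2-fold lower number from compound 3 to compound 4 (0.08 log units; within the scatter) that may well fall within the scatter, and estimates for compound 4 a value of 250 nM, between 80 nM and 800 nM.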

Compound 4, half-maximal inhibitory concentration: 110 nM
Compound 4: the middle estimate sits 2.3-fold (0.36 log units) above what was measured, within the range that was stated.
By their numbers in this assay, from the lowest: compounds 4 and 2 (each within the scatter of the next); then compound 3. At a limit, above all of these: compound 1.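

Joining the chain into a ring is tolerated at this position, and in this assay it even gives a modest gain over the methylamino chain, with a 2.7-fold lower number from compound 3 to compound 4 (0.44 log units; beyond the scatter). The ring does not separate from the primary amine chain, however, with a 1.2-fold lower number from compound 2 to compound 4 (0.07 log units; within the scatter), so among the three compounds with a substituted alkyne, only the 2-hydroxy-1-(methylamino)ethyl group of compound 3 stands apart, and a ring is not needed to reach the level of compound 2. The replacement of iodo again has a large effect, but it is known only as a bound, an at least 270-fold lower number from compound 1 to compound 4 (2.43 log units; beyond the scatter), since compound 1 is a limit of the assay rather than a number: the limit of > 30000 nM in this assay, at which 1 of the 4 values shown sits.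

Going by these compounds, it remains open how far the hydroxyl on the ring matters, as a plain pyrrolidin-2-yl group on the triple-bonded carbon has no value here, and a six-membered piperidin-2-yl ring is likewise unexplored in these compounds. The part played by the two defined stereocentres of compound 4 is also open, as no other stereoisomer of this ring is shown.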